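Swapping the Aryl Group on a Urea Nitrogen

The compounds below may be only part of what the source reports. "The series", "measured", "known", "first", "only" and "open" are said of these compounds alone.

Of the compounds shown here, two with a shared core have so far been measured in a functional assay on MGC-803 cells (Homo sapiens) for antiproliferative activity, read by MTT assay; on this read-out lower numbers stand for stronger inhibition and higher numbers for weaker inhibition. Compound 1 `COc1cc2ncnc(NCc3cccc(NC(=O)Nc4cccc(C)c4)c3)c2cc1OC` gives 44600 nM. Compound 2 `COc1cc2ncnc(NCc3cccc(NC(=O)Nc4ccc(C(C)(C)C)cc4)c3)c2cc1OC` gives 6790 nM, the lowest of the two numbers. For the measured compounds named here, the single step between them, a 6.6-fold lower number from compound 1 to compound 2 (0.82 log units; beyond the scatter), shows that the aryl group on the amide-type nitrogen can shift the read-out well beyond the scatter. Compound 3 `COc1cc2ncnc(NCc3cccc(NC(=O)Nc4ccccc4F)c3)c2cc1OC` has not yet been measured; it differs from compound 2 by 2-fluorophenyl in place of 4-(tert-butyl)phenyl on an amide-type nitrogen. Going by the values given here, only the step from compound 1 to compound 2 bears on this change, and it ran from a 3-methylphenyl group to a 4-(tert-butyl)phenyl group with a clear drop in the number. Replacing 4-(tert-butyl)phenyl by 2-fluorophenyl is expected to move the number back up, by about a 4.4-fold higher number from compound 2 to compound 3 (0.65 log units; beyond the scatter) in this assay. Compound 3 is therefore estimated at 30000 nM, with a range from 8000 nM to 100000 nM.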

Compound 3, half-maximal inhibitory concentration: 10300 nM
Estimate against measurement, compound 3: 2.9-fold (0.46 log units) above; measured number inside the range.
By their numbers in this assay, from the lowest: compounds 2 and 3 (each within the scatter of the next); then compound 1.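

In this assay, the step of a 1.5-fold higher number from compound 2 to compound 3 (0.18 log units; within the scatter) lies within the scatter, so 2-fluorophenyl cannot be told apart from 4-(tert-butyl)phenyl on this amide-type nitrogen. The step of a 4.3-fold lower number from compound 1 to compound 3 (0.64 log units; beyond the scatter) lies beyond the scatter, so compound 1 with its 3-methylphenyl group now stands apart from two differently substituted aryl groups rather than just one. Nothing measured here explains why these groups compare as they do.

The compounds shown leave open how a plain phenyl group, a phenyl ring carrying a nitrile or a carboxylic acid, or an alkyl chain would compare on this nitrogen. They also cannot separate the identity of a substituent from where it sits on the ring, since the three aryl groups differ in both.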